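Amide nitrogen exchange, compound 3 to compound 4

The source may report more compounds than this note shows. Statements on the series, on what has been measured and on what is new or still open speak of the compounds shown alone.

Three compounds of the series, compound 1 `COc1cc(-c2cc(C(=O)O)c3ccccc3n2)ccc1OCC(=O)Nc1cccc(F)c1`, compound 2 `COc1cc(-c2cc(C(=O)O)c3ccccc3n2)ccc1OCC(=O)Nc1ccccc1C(F)(F)F` and compound 3 `COc1cc(-c2cc(C(=O)O)c3ccccc3n2)ccc1OCC(=O)Nc1ccc(C(F)(F)F)cc1`, have been run in a physicochemical assay for lipophilicity, using the shake flask method, in phosphate buffer, measured as octanol-water partition, at pH 7.4; on this read-out higher numbers stand for higher lipophilicity and lower numbers for lower lipophilicity. Compound 1 gives 1.6, compound 2 gives 1.3 and compound 3 gives 1.6. Compound 3 stands level with compound 1, the two together the highest of the three numbers; its furthest neighbour is compound 2, with a number 0.30 log units higher from compound 2 to compound 3 (within the scatter). The other steps, a number 0.30 log units lower from compound 1 to compound 2 (within the scatter) and no change at the digits printed from compound 1 to compound 3 (within the scatter), also stay inside the scatter: swapping one substituted phenyl for another on the amide nitrogen has not moved the read-out beyond it.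

Compound 4 `COc1cc(-c2cc(C(=O)O)c3ccccc3n2)ccc1OCC(=O)NCc1ccco1` is not yet measured. Its difference from compound 3 is (furan-2-yl)methyl in place of 4-(trifluoromethyl)phenyl on an amide-type nitrogen. Going by the values given here, none of the measured steps covers this kind of exchange: each kept a six-membered carbon-only aromatic ring on the amide nitrogen, whereas here that ring leaves and a five-membered ring with one hetero atom and an added carbon enters. The measured steps give no direct size for this change, so the expectation rests on what leaves and what enters. A step of a number 0.60 log units lower from compound 3 to compound 4 (beyond the scatter) toward a lower number is expected. Compound 4 is estimated at 1, within a range from 0.5 to 1.5.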

Compound 4, distribution coefficient: -0.3
Estimate against measurement, compound 4: 1.30 log units above, outside the stated range (below it).
By their numbers in this assay, from the lowest: compound 4; then compounds 2, 1 and 3 (each within the scatter of the next).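

In this assay the amide-type nitrogen proves responsive once the substituted phenyl group gives way to (furan-2-yl)methyl, with a number 1.90 log units lower from compound 3 to compound 4 (beyond the scatter) and a number 1.90 log units lower from compound 1 to compound 4 (beyond the scatter) as well as a number 1.60 log units lower from compound 2 to compound 4 (beyond the scatter) for the same kind of exchange. The earlier exchanges, each from one substituted phenyl to another, stayed within the scatter, so this position is not indifferent to every change made there. No measurement accompanying this result bears on what lies behind the step.

The exchange alters the ring and adds a carbon in one move, and the compounds shown do not separate these two parts. A benzyl group on the amide-type nitrogen would test the added carbon with a six-membered carbon-only aromatic ring retained, while leaving open how far the furan ring itself counts.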